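Swapping the Aryl Group of Compound 1 for a Hydroxy-Methoxy Ring

The source may hold more compounds than are shown below. What is called first, only, known or untested is meant among the compounds shown, and "the series" means these compounds.

Compound 1 `OC[C@H]1O[C@@H](n2cnc3c(NCc4cccc(F)c4)ncnc32)[C@H](O)[C@@H]1O` and compound 2 `OC[C@H]1O[C@@H](n2cnc3c(NCc4ccc(Cl)c(Cl)c4)ncnc32)[C@H](O)[C@@H]1O` share one core and differ only in the phenyl group carried on a saturated chain carbon bound to a nitrogen on an aromatic ring. In a functional assay on CCRF-CEM cells (Homo sapiens) for antiproliferative activity, with a stated time of 72 h (a lower number here means a stronger inhibitor, a higher number a weaker inhibitor), compound 1 gives 4000 nM, the higher of the two numbers shown, and compound 2 gives 3800 nM, a difference within the scatter. The step of a 1.1-fold lower number from compound 1 to compound 2 (0.02 log units; within the scatter) shows that putting 3,4-dichlorophenyl in place of 3-fluorophenyl changed little.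

Compound 3 `COc1cccc(CNc2ncnc3c2ncn3[C@@H]2O[C@H](CO)[C@@H](O)[C@H]2O)c1O` is not yet measured. It differs from compound 1 as follows: 2-hydroxy-3-methoxyphenyl in place of 3-fluorophenyl on a saturated chain carbon bound to a nitrogen on an aromatic ring. Going by the values given here, the only measured step, from compound 1 to compound 2, stayed within the scatter, and no measured pair introduces a hydroxy or methoxy group, so nothing shows how this change acts here. The expectation is therefore a step of about no change at the digits printed from compound 1 to compound 3 (within the scatter), with no direction beyond the scatter. Compound 3 is estimated at 4000 nM, within a range from 1500 nM to 12000 nM.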

Compound 3, half-maximal inhibitory concentration: 300 nM
Beside the measured number, compound 3's estimate is 13-fold (1.12 log units) above it; the whole stated range lies above it.
By their numbers in this assay, from the lowest: compound 3; then compounds 2 and 1 (each within the scatter of the next).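

In this assay the aryl group on a saturated chain carbon bound to a nitrogen on an aromatic ring turns out to matter a great deal: 2-hydroxy-3-methoxyphenyl in place of 3-fluorophenyl gives a 13-fold lower number from compound 1 to compound 3 (1.12 log units; beyond the scatter) and in place of 3,4-dichlorophenyl gives a 13-fold lower number from compound 2 to compound 3 (1.10 log units; beyond the scatter). The earlier pair, whose values lay within the scatter, gave no sign that this position could respond so strongly to a change of group. Unlike the 3-fluorophenyl group, the entering group has a hydrogen-bond donor and hydrogen-bond acceptors, but no measurement here explains the drop.

The hydroxy and methoxy groups appear only together, leaving open whether either alone would give such a step. Also open, as far as these compounds go, is how a ring carrying an amine or a carboxylic acid would behave in this position.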